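Flavone oxime ethers: fluoro-to-methoxy swap on the pendant ring

A few compounds are considered here, and "the series" means these few. Any claim that something is new, unique, unknown or untested is made for them only; others in the source may bear on it.

Compound 1 `O=c1cc(-c2ccccc2)oc2ccc(OC/C(=N/O)c3ccc(F)cc3)cc12` and compound 3 `O=c1cc(-c2ccccc2)oc2cc(OC/C(=N/O)c3ccc(F)cc3)ccc12` are built from the same atoms joined differently; the difference between the two cores is not broken down here. In a functional assay on SK-HEP1 cells (Homo sapiens) for antiproliferative activity (on this read-out lower numbers stand for stronger inhibition of growth and higher numbers for weaker inhibition of growth), compound 1 gives 2800000 nM and compound 3 gives 2300000 nM, the two lying within the scatter of each other. Compound 2 `COc1ccc(/C(COc2ccc3oc(-c4ccccc4)cc(=O)c3c2)=N\O)cc1` carries the change methoxy in place of fluoro on an aromatic carbon relative to compound 1, and in this assay compound 2 gives 800000 nM, a step of a 3.5-fold lower number from compound 1 to compound 2 (0.54 log units; beyond the scatter). Compound 4 `COc1ccc(/C(COc2ccc3c(=O)cc(-c4ccccc4)oc3c2)=N\O)cc1` applies the same change to compound 3, namely (methoxy in place of fluoro on an aromatic carbon). Going by the values given here, since the change is the same and the starting values of compound 1 and compound 3 sit close together, a step of similar size is expected, a 3.5-fold lower number from compound 3 to compound 4 (0.54 log units; beyond the scatter), resting on the single measured pair. Compound 4 is therefore estimated at 660000 nM in this assay, between 300000 nM and 1500000 nM.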

Compound 4, concentration for 50% growth inhibition: 5600000 nM
Estimate against measurement, compound 4: 8.5-fold (0.93 log units) below, and the stated range ends below it.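

On the core of compound 3, the change from 4-fluorophenyl to 4-methoxyphenyl gives in this assay a 2.4-fold higher number from compound 3 to compound 4 (0.39 log units; beyond the scatter), opposite in direction to the step on the core of compound 1: the same change on two cores in this assay, a 3.5-fold lower number (0.54 log units; beyond the scatter) from compound 1 to compound 2 and a 2.4-fold higher number (0.39 log units; beyond the scatter) from compound 3 to compound 4, 8.5-fold (0.93 log units) apart, beyond the scatter of two such steps

The outcome of this change therefore depends on the core in these two pairs, and a step measured on one core cannot be carried over to the other. With a single pair on each core, this does not show why the two cores differ or how any other group would behave on them.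

Open, on these data alone, is how an amine or a carboxylic acid in place of fluoro would read on each core. Also open, as far as these compounds go, is whether a longer alkoxy chain in place of methoxy would keep the same difference between the two cores.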